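The source may report more compounds than this note shows. Statements on the series, on what has been measured and on what is new or still open speak of the compounds shown alone.

Compound 1, with the structure `CCCc1ccc(/C=C/C(=O)Nc2ccc3nc(CCC)cc(N)c3c2)cc1`, is measured in a functional assay on HEK293 cells for activation of melanin-concentrating hormone receptor 1 (Homo sapiens), read by inositol phosphate accumulation (a lower number here means that less compound is needed, a higher number that more compound is needed for the effect), where it gives 3600 nM. Among the three measured compounds this is the highest number: compound 3 `CCCc1cc(N2CCC2)c2cc(NC(=O)/C=C/c3ccc(C(F)(F)F)cc3)ccc2n1` gives 2500 nM, which lies within the scatter of compound 1, while compound 2 `CCC(C)c1cc(N)c2cc(NC(=O)/C=C/c3ccc(C(F)(F)F)cc3)ccc2n1` gives 44 nM, a far lower number, beyond the scatter. Compound 4 `CCCc1cc(N)c2cc(NC(=O)/C=C/c3ccccc3Cl)ccc2n1` is not yet measured; it differs from compound 1 in one place: 2-chlorophenyl in place of 4-propylphenyl on a double-bonded chain carbon bound to a double-bonded chain carbon. Compound 2 shows that replacing the group on this chain carbon can shift the number strongly, so a moderate step downward is expected from compound 1 to compound 4, a 4.0-fold lower number from compound 1 to compound 4 (0.60 log units; beyond the scatter), though the direction is uncertain. For compound 4 the expected value in this assay is 900 nM, within a range from 150 nM to 5000 nM.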

Compound 4, half-maximal effective concentration: 500 nM
The estimate for compound 4 lay 1.8-fold (0.26 log units) above the measured number, and the stated range covers the measured number.
By their numbers in this assay, from the lowest: compound 2; then compound 4; then compounds 3 and 1 (each within the scatter of the next).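

Going by these compounds alone, this is the first step in this assay that changes only the group on this chain carbon: 2-chlorophenyl in place of 4-propylphenyl gives a 7.2-fold lower number from compound 1 to compound 4 (0.86 log units; beyond the scatter). It shows that this position alone can move the number beyond the scatter, even when the shared core stays the same. The step swaps the propyl chain for chlorine and also changes where the group sits on the ring, and no measurement here accounts for the shift.

Which of these two differences matters remains open. Plain phenyl and 4-chlorophenyl on the same core would help separate them.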